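A few compounds are considered here, and "the series" means these few. Any claim that something is new, unique, unknown or untested is made for them only; others in the source may bear on it.

Of the compounds shown here, three sharing one core have been measured in a functional assay on MDA-MB-231 cells (Homo sapiens) for inhibition, read by MTT assay, with a stated time of 72 h; a lower number here means a stronger inhibitor, a higher number a weaker inhibitor. Compound 1 `O=C(CSc1nc(Nc2ccccc2)c2ccccc2n1)Nc1cccc(Cl)c1` gives 16500 nM. Compound 2 `O=C(CSc1nc(Nc2ccccc2)c2ccccc2n1)Nc1cccc([N+](=O)[O-])c1` gives 33000 nM, and compound 3 `O=C(CSc1nc(Nc2ccccc2)c2ccccc2n1)Nc1ccc(F)cc1` gives 34100 nM, the highest of the three numbers, although compound 2 sits within the usual scatter of it. Among the measured compounds shown here, the only step that stands out is a 2.1-fold higher number from compound 1 to compound 3 (0.32 log units; beyond the scatter), a modest shift; a 2.0-fold higher number from compound 1 to compound 2 (0.30 log units; within the scatter) and a 1.0-fold higher number from compound 2 to compound 3 (0.01 log units; within the scatter) are both within the scatter.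

Compound 4 `O=C(CSc1nc(Nc2ccccc2)c2ccccc2n1)Nc1ccc(Cl)cc1Cl` differs from compound 3 by 2,4-dichlorophenyl in place of 4-fluorophenyl on an amide-type nitrogen. For the measured compounds named here, the step that bears most directly on this change is a 2.1-fold higher number from compound 1 to compound 3 (0.32 log units; beyond the scatter), since that step exchanged a chlorine-bearing ring for the 4-fluorophenyl group and brought a modestly higher number; going back from the 4-fluorophenyl group to a chlorine-bearing ring might reverse that, but no measured compound carries two chlorines on this ring, so the weight of the second chlorine is untested. In this assay the expectation for compound 4 is therefore a modest move toward a lower number, roughly a 1.7-fold lower number from compound 3 to compound 4 (0.23 log units; within the scatter), with wide uncertainty. Compound 4 is thus estimated at 20000 nM, within a range of 8000 nM to 50000 nM.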

Compound 4, half-maximal inhibitory concentration: 19400 nM
Compound 4: the middle estimate sits 1.0-fold (0.01 log units) above what was measured, and the stated range covers the measured number.
By their numbers in this assay, from the lowest: compounds 1, 4, 2 and 3 (each within the scatter of the next, the first and the last beyond it).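

In this assay, putting 2,4-dichlorophenyl in place of 3-chlorophenyl on the amide-type nitrogen gives a 1.2-fold higher number from compound 1 to compound 4 (0.07 log units; within the scatter), so a ring with two chlorines cannot be told apart from the ring with one. The same group in place of 4-fluorophenyl gives a 1.8-fold lower number from compound 3 to compound 4 (0.24 log units; within the scatter), and in place of 3-nitrophenyl it gives a 1.7-fold lower number from compound 2 to compound 4 (0.23 log units; within the scatter), so compound 4 also stays within the scatter of the two compounds that carry no chlorine, even though compound 1 and compound 3 are separated by a modest step beyond it. All four substituted phenyl groups at this place therefore fall in one narrow band, and nothing at hand accounts for that narrowness.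

The compounds shown leave open whether anything on this nitrogen can move the number far from that band, for instance a phenyl ring bearing a carboxylic acid or an amine, or a longer chain in place of the ring. They also say nothing about changes elsewhere, since the shared core stays the same in all four compounds.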